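Dropping the Phenyl: Expected Cytotoxicity of Compound 4

A few compounds are considered here, and "the series" means these few. Any claim that something is new, unique, unknown or untested is made for them only; others in the source may bear on it.

Compound 1 `CCCNC(=O)C1CCN(C(=O)c2cc3sc(-c4ccccc4)nc3n2Cc2ccc(OC)cc2)CC1`: 22900 nM
Compound 2 `CCCNC(=O)C1CCN(C(=O)c2cc3oc(Br)cc3n2Cc2ccc(OC)cc2)CC1`: 21900 nM
Compound 3 `CCCNC(=O)C1CCN(C(=O)c2cc3cc(Br)sc3n2Cc2ccc(OC)cc2)CC1`: a limit of the assay, > 100000 nM

The three measured compounds share the propylamide piperidine amide and the methoxybenzyl group and differ only in the fused core. In an ADME assay on HEK-293T cells (Homo sapiens) for cytotoxicity, read by luminescence and CellTiter-Glo, with a stated time of 24 h (on this read-out higher numbers stand for lower toxicity in this test and lower numbers for higher toxicity in this test), compound 1 gives 22900 nM and stands highest of the two numbers that are not limits. Its nearest neighbour, compound 2, gives 21900 nM in this assay, a difference that lies within the usual scatter, so the two cannot be told apart. For compound 3 the assay reports only a limit, > 100000 nM, as noted in the limit of > 100000 nM in this assay, at which 1 of the 3 values shown sits. For the measured compounds named here, no step between two measured compounds that differ in a single place is available, so the comparison of compound 1 with compound 4 rests on the structural change alone.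

Compound 4 `CCCNC(=O)C1CCN(C(=O)c2cc3scnc3n2Cc2ccc(OC)cc2)CC1` is the analogue of compound 1 in which the phenyl is removed: hydrogen in place of phenyl on an aromatic carbon. The step of a 1.7-fold higher number from compound 1 to compound 4 (0.24 log units; within the scatter) is the one expected here, pointing toward a somewhat higher number, though possibly no further than the scatter allows. On that basis compound 4 is estimated at 40000 nM in this assay, with a range from 15000 nM to 100000 nM, and a fair chance that only a limit is reported.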

Compound 4, half-maximal cytotoxic concentration: 19100 nM
Estimate against measurement, compound 4: 2.1-fold (0.32 log units) above; the range from low to high includes it.
By their numbers in this assay, from the lowest: compounds 4, 2 and 1 (each within the scatter of the next). At a limit, above all of these: compound 3.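

Replacing the phenyl with hydrogen on an aromatic carbon of the five-membered aromatic ring with 1 nitrogen and 1 sulfur gives, in this assay, a 1.2-fold lower number from compound 1 to compound 4 (0.08 log units; within the scatter). This pair is the only direct reading at this position among the compounds shown, as the earlier compounds offered no two that differ in one place, and it shows that taking away the phenyl, with its 6 heavy atoms and six-membered aromatic ring of carbon only, leaves the number indistinguishable from that of compound 1. Nothing shown here accounts for this absence of a measurable change.

As far as these compounds go, whether this carbon accepts other substituents just as quietly remains open: an amine, a carboxylic acid, a methoxy group or a longer alkyl chain in the same place could give a different reading from either hydrogen or phenyl. It is also open whether a phenyl in place of the bromine on the other cores shown would leave their numbers equally unchanged.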